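Trifluoromethyl to Fluoro on a Diaryl Urea

The source may hold more compounds than are shown below. What is called first, only, known or untested is meant among the compounds shown, and "the series" means these compounds.

Compound 1 `CC(=O)Nc1cc(NC(=O)Nc2cc(C(F)(F)F)cc(C(F)(F)F)c2)ccc1C` gives 685 nM in a functional assay on A375P cells (Homo sapiens) for antiproliferative activity; on this read-out higher numbers stand for weaker inhibition and lower numbers for stronger inhibition. Compound 2 `CC(=O)Nc1cc(NC(=O)Nc2cc(F)cc(C(F)(F)F)c2)ccc1C` reaches only the limit > 30000 nM in this assay, which is a limit and not a number. Compound 3 `Cc1ccc(NC(=O)Nc2cc(C(F)(F)F)cc(C(F)(F)F)c2)cc1NC(=O)c1ccccc1` gives 162 nM in this assay.

Compound 3 stands lowest of the two numbers shown; the step between them is a 4.2-fold lower number from compound 1 to compound 3 (0.63 log units; beyond the scatter). Compound 4 `Cc1ccc(NC(=O)Nc2cc(F)cc(C(F)(F)F)c2)cc1NC(=O)c1ccccc1` differs from compound 3 by fluoro in place of trifluoromethyl on an aromatic carbon. The same change has been seen once before: an at least 43-fold higher number from compound 1 to compound 2 (1.64 log units; beyond the scatter). Compound 2 is at the limit of > 30000 nM in this assay, at which 1 of the 3 values shown sits. A step of comparable size in this assay is therefore expected, towards weaker inhibition, as a 93-fold higher number from compound 3 to compound 4 (1.97 log units; beyond the scatter). Compound 4 is expected to give about 15000 nM, within 4000 nM to 60000 nM, with a fair chance that only a limit is reported.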

Compound 4, half-maximal inhibitory concentration: > 30000 nM
Compound 4 ended at the assay's limit; the forecaster's own chance of this, stated with the estimate: 45%; middle value at least 2.0-fold (0.30 log units) away from the limit.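

Fluoro in place of trifluoromethyl is now seen to be costly on the core of compound 3 as well, where phenyl replaces methyl on the carbonyl carbon, with an at least 180-fold higher number from compound 3 to compound 4 (2.26 log units; beyond the scatter). Compound 2 and compound 4 both stand at a limit of the assay, so the step between them cannot be read, and any benefit of phenyl over methyl is hidden once fluoro is present. Neither core shown goes against this pattern: the same change on two cores in this assay, an at least 43-fold higher number (1.64 log units; beyond the scatter) from compound 1 to compound 2 and an at least 180-fold higher number (2.26 log units; beyond the scatter) from compound 3 to compound 4; the limit leaves it open whether they differ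

As far as these compounds go, whether the loss is equally large on both cores stays open. So does what an amine, a methoxy group or a chlorine atom at this position would give in this assay.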